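Hydroxy on the anilino group of compound 3

This account rests on a few compounds, and the source may have more. Where it says the series, first, only, none or still open, it means among the compounds named here.

Of the compounds shown here, three sharing one core have been read in a functional assay on MCF7 cells (Homo sapiens) for inhibition, read by fluorescence, with a stated time of 72 h; on this read-out lower numbers stand for stronger inhibition of growth and higher numbers for weaker inhibition of growth. Compound 1 (`COc1ccc(Nc2nc(N[C@H]3CC[C@H](N)CC3)nc3c2ncn3CCC(C)C)c(OC)c1`) gives 6300 nM, compound 2 (`CC(C)CCn1cnc2c(NCc3cccc(Cl)c3)nc(N[C@H]3CC[C@H](N)CC3)nc21`) gives 4700 nM and compound 3 (`CC(C)CCn1cnc2c(Nc3ccccc3)nc(N[C@H]3CC[C@H](N)CC3)nc21`) gives 5400 nM. Compound 3 stands among these numbers with no separation from the other two, as the steps show: a 1.2-fold lower number from compound 1 to compound 3 (0.07 log units; within the scatter) and a 1.1-fold higher number from compound 2 to compound 3 (0.06 log units; within the scatter).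

Compound 4 (`CC(C)CCn1cnc2c(Nc3cccc(O)c3)nc(N[C@H]3CC[C@H](N)CC3)nc21`) keeps everything in compound 3 except the anilino group, which becomes (3-hydroxyphenyl)amino: hydroxy in place of hydrogen on an aromatic carbon. Among the compounds with values here, no measured step adds a hydroxy, so the evidence is indirect. The measured steps all concern the group on the same nitrogen, and the third of them is a 1.3-fold lower number from compound 1 to compound 2 (0.13 log units; within the scatter). Across 2,4-dimethoxyphenyl, 3-chlorobenzyl and phenyl, then, no step exceeds the scatter, though this covers three compounds only and none carries a hydroxy.

On that basis, the expected step in this assay is a 1.2-fold lower number from compound 3 to compound 4 (0.08 log units; within the scatter), which means no real change is anticipated. For compound 4 the estimated value is 4500 nM, with an expected range from 2000 nM to 10000 nM.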

Compound 4, concentration for 50% growth inhibition: 12600 nM
Compound 4: middle estimate off by 2.8-fold (0.45 log units), on the low side; the measured number lies above the stated range.
By their numbers in this assay, from the lowest: compounds 2, 3, 1 and 4 (each within the scatter of the next, the first and the last beyond it).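

In this assay, the group on this nitrogen no longer looks indifferent to change: the earlier replacements all stayed within the scatter, whereas hydroxy in place of hydrogen on an aromatic carbon, meta to a large group, gives a 2.3-fold higher number from compound 3 to compound 4 (0.37 log units; beyond the scatter) and so weakens inhibition of growth. The separation also appears against the 3-chlorobenzyl compound, with a 2.7-fold higher number from compound 2 to compound 4 (0.43 log units; beyond the scatter), but it does not hold against the 2,4-dimethoxyphenyl compound, where a 2.0-fold higher number from compound 1 to compound 4 (0.30 log units; within the scatter) leaves compound 4 and compound 1 unseparated, so the hydroxy effect is real only in the comparisons with compound 2 and compound 3. Nothing available on these compounds accounts for the modest step from hydrogen to hydroxy.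

Going by these compounds, it remains open whether this weakening belongs to hydroxy specifically or would also follow from a methoxy, an amine or a carboxylic acid on the same aromatic carbon. On these data alone, it is equally open whether a hydroxy on another carbon of the phenyl ring, or on the benzyl ring of compound 2, would give a step of similar size.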